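The source may hold more compounds than are shown below. What is called first, only, known or untested is meant among the compounds shown, and "the series" means these compounds.

Three compounds of one shared core differ only in the group carried on the aniline ring. In a functional assay on SK-OV-3 cells (Homo sapiens) for cytotoxicity, read by MTT assay, with a stated time of 72 h (a higher number here means a weaker inhibitor, a lower number a stronger inhibitor), compound 1 `O=C1C(Nc2ccc(F)cc2)=CC(=O)c2ncncc21` gives 0.07 ug/mL, and compound 3 `O=C1C(Nc2ccc(I)cc2)=CC(=O)c2ncncc21` gives 0.04 ug/mL, a step of a 1.8-fold lower number from compound 1 to compound 3 (0.24 log units; within the scatter), so these two cannot be told apart on this assay. Compound 2 `O=C1C(Nc2ccccc2)=CC(=O)c2ncncc21` reaches only the limit of the assay, < 0.01 ug/mL, which is a limit and not a number (the limit of < 0.01 ug/mL in this assay, at which 1 of the 3 values shown sits). Against that limit the steps are an at least 7.0-fold lower number from compound 1 to compound 2 (0.84 log units; beyond the scatter) and an at least 4.0-fold higher number from compound 2 to compound 3 (0.60 log units; beyond the scatter), and both are floors on the true distance between compound 2 and the two halogenated compounds.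

Compound 4 `O=C1C(Nc2ccc(Cl)cc2)=CC(=O)c2ncncc21` differs from compound 2 by chloro in place of hydrogen on an aromatic carbon. For the measured compounds named here, the steps that bear on this are an at least 4.0-fold higher number from compound 2 to compound 3 (0.60 log units; beyond the scatter), where a halogen enters at the same place, and, read in reverse, an at least 7.0-fold lower number from compound 1 to compound 2 (0.84 log units; beyond the scatter). Both are at least modest and both run toward higher numbers when a halogen enters; compound 1 and compound 3 lie within the scatter of each other, so the choice of halogen has not separated them here. The step from compound 2 to compound 4 is therefore expected to be upward and beyond the scatter, an at least 5.0-fold higher number from compound 2 to compound 4 (0.69 log units; beyond the scatter). Compound 4 is estimated at 0.05 ug/mL, within a range from 0.015 ug/mL to 0.15 ug/mL.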

Compound 4, half-maximal inhibitory concentration: 0.01 ug/mL
Estimate against measurement, compound 4: 5.0-fold (0.70 log units) above; the measured number lies below the stated range.
By their numbers in this assay, from the lowest: compound 4; then compounds 3 and 1 (each within the scatter of the next).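

Chloro on this aromatic carbon, para to a large group, separates from both other halogens in this assay: there is a 4.0-fold lower number from compound 3 to compound 4 (0.60 log units; beyond the scatter), and there is a 7.0-fold lower number from compound 1 to compound 4 (0.85 log units; beyond the scatter). The earlier compounds gave no such separation, as fluoro and iodo lie within the scatter of each other, so the identity of the halogen at this position can matter, although the three halogens shown do not fall into a simple progression from fluoro to iodo, with chloro standing apart from both and compound 1 and compound 3 remaining unresolved. Compound 2 carries only a limit of the assay and not a number: the limit of < 0.01 ug/mL in this assay, at which 1 of the 4 values shown sits. Against that limit the data give a number no lower from compound 2 to compound 4 (the limit leaves the size open), so the size of the step between hydrogen and chloro at this position cannot be read and stays unknown.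

Still open, from the compounds shown here alone, is how bromo, a methoxy group, an amine or a carboxylic acid on this same carbon would stand against chloro. The compounds shown also leave open whether the separation of chloro from fluoro and iodo would hold on any cell line other than this one.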